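Adding a Second Fluorine to an Oxime Analogue

A few compounds are considered here, and "the series" means these few. Any claim that something is new, unique, unknown or untested is made for them only; others in the source may bear on it.

Compound 2 `Cc1c(/C=N\O)cc(-c2ccc(S(C)(=O)=O)cc2)n1-c1ccc(F)cc1` stands lowest of the two numbers in hand: in a functional assay on the whole organism (strain Swiss albino) for inhibition, with Mus musculus as the target, in the writhing test, with a stated time of 30 min, at a dose of 10 mg/kg by the oral route (a lower number here means a weaker effect, a higher number a stronger effect of the compound at the dose given), compound 2 gives 36%, while compound 1 `Cc1c(C=O)cc(-c2ccc(S(C)(=O)=O)cc2)n1-c1ccc(F)c(F)c1` gives 53%, a gap beyond the usual scatter. Among the measured compounds shown here, no single-point step connects these two, so their values are simply stated side by side. Compound 3 `Cc1c(/C=N\O)cc(-c2ccc(S(C)(=O)=O)cc2)n1-c1ccc(F)c(F)c1` differs from compound 2 by fluoro in place of hydrogen on an aromatic carbon. For this change an upward step in this assay of moderate size is expected, likely beyond the scatter but not large. Compound 3 is therefore estimated at 45%, within 25% to 65%, a step of a number 9 percentage points higher from compound 2 to compound 3 (within the scatter).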

Compound 3, a percentage reported as inhibition, in the whole organism at one dose (the size of the read-out at that dose, not a potency): 19%
Compound 3: middle estimate off by 26 percentage points, on the high side, outside the stated range (below it).
By their numbers in this assay, from the lowest: compound 3; then compound 2; then compound 1.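

Fluoro in place of hydrogen, taking 4-fluorophenyl to 3,4-difluorophenyl, gives a number 17 percentage points lower from compound 2 to compound 3 (beyond the scatter) in this assay, so this ring position is not silent in the oxime compounds. With the 3,4-difluorophenyl group held fixed, the oxime in place of the formyl group gives a number 34 percentage points lower from compound 1 to compound 3 (beyond the scatter), a large step. No measurement at hand accounts for either step. Going by these compounds, whether the fluoro step would look the same on a formyl compound remains open. So does how a chloro or methoxy group at this position, or a nitrile or carboxylic acid in place of the oxime, would read.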